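From bromo to iodo on compound 1

The source may hold more compounds than are shown below. What is called first, only, known or untested is meant among the compounds shown, and "the series" means these compounds.

Compound 1 `NC(=O)c1cc(Br)ccc1NC(=O)/C=C/c1ccccc1Cl`: 59%
Compound 2 `NC(=O)c1cc(Br)ccc1NC(=O)/C=C/c1ccccc1Br`: 46.2%

Both compounds were tested in a functional assay on K562 cells (Homo sapiens) for antiproliferative activity, read by trypan blue exclusion, with a stated time of 48 h, tested at 10 uM; a higher number here means more inhibition of growth at the concentration tested, a lower number less inhibition of growth. Compound 1 stands higher of the two, at 59%, while compound 2 reaches 46.2%. The next compound to be tested is compound 3 `NC(=O)c1cc(I)ccc1NC(=O)/C=C/c1ccccc1Cl`, which keeps the core of compound 1 and changes one halogen: iodo in place of bromo on an aromatic carbon. This is iodo in place of bromo on an aromatic carbon, meta to a carbamoyl group and para to a large group.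

Among the compounds with values here, only one measured step bears on this change: a number 12.8 percentage points lower from compound 1 to compound 2 (beyond the scatter). That step also replaces one halogen with another, but it does so at a different place in the molecule and does not involve iodo. It is therefore only a loose guide. A fall in the same direction is expected, though smaller than that step and possibly within the scatter.

The expected change is a number 5 percentage points lower from compound 1 to compound 3 (within the scatter). For compound 3 the estimated value is 54%, with an expected range from 38% to 70%.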

Compound 3, percent growth inhibition at one concentration: 74.1%
Compound 3: the middle estimate sits 20.1 percentage points below what was measured, outside the stated range (above it).
By their numbers in this assay, from the lowest: compound 2; then compound 1; then compound 3.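

In this assay the exchange of bromo for iodo, on an aromatic carbon meta to a carbamoyl group and para to a large group, gives a number 15.1 percentage points higher from compound 1 to compound 3 (beyond the scatter) and so shows that this position is not indifferent to which halogen it carries. Within the data shown here, the only earlier step, a number 12.8 percentage points lower from compound 1 to compound 2 (beyond the scatter) as one halogen replaced another at a different place in the molecule, ran in the opposite direction, so a halogen exchange at one place gave no guide to an exchange at the other in these compounds. No measurement among those shown bears on why the number rises with iodo at this position.

The compounds shown leave open whether chloro or fluoro at this position, or a group without a halogen such as an amine or a methoxy group, would give a number above or below that of the iodo compound. They also leave open whether iodo at this position would keep its advantage over bromo with bromo in place of chloro on the other aromatic ring.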